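Trimethoxyphenyl pyrazole chalcones: dropping one methoxy

This account rests on a few compounds, and the source may have more. Where it says the series, first, only, none or still open, it means among the compounds named here.

The series shares a trimethoxyphenyl pyrazole linked through an alkene to an aryl ketone, and is followed in a functional assay on KM12 cells (Homo sapiens) for cytotoxicity, read by sulforhodamine B assay, with a stated time of 48 h, tested at 0.01 uM; a lower number here means a stronger effect, a higher number a weaker effect of the compound at the concentration tested. Compound 1 `COc1cc(-c2cc(/C=C/C(=O)c3ccc(N)cc3)[nH]n2)cc(OC)c1OC` carries a 4-aminophenyl on the carbonyl carbon; in this assay compound 1 gives 102%. Compound 2 `COc1ccc(C(=O)/C=C/c2cc(-c3cc(OC)c(OC)c(OC)c3)n[nH]2)cc1OC` carries a 3,4-dimethoxyphenyl on the same carbonyl carbon; in this assay compound 2 gives 97%. The step of a number 5 percentage points lower from compound 1 to compound 2 (within the scatter) is within the scatter, so neither compound can be ordered against the other. Among the measured compounds shown here, compound 2 stands at the lower of the two numbers, with compound 1 its only neighbour and within the scatter of it.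

Compound 3 `COc1ccc(C(=O)/C=C/c2cc(-c3cc(OC)c(OC)c(OC)c3)n[nH]2)cc1` is not yet measured. It differs from compound 2 in hydrogen in place of methoxy on an aromatic carbon, cut one bond further out a 3,4-dimethoxyphenyl to 4-methoxyphenyl exchange. For the measured compounds named here, the only measured step, the one from compound 1 to compound 2, also sits on this aryl and did not move the read-out beyond the scatter. On that basis the step of no change at the digits printed from compound 2 to compound 3 (within the scatter) is expected to stay within the scatter. Compound 3 is therefore estimated at 97%, with a range from 85% to 108%.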

Compound 3, a percentage reported as activity, at one concentration (the size of the read-out at that concentration, not a potency): 99%
Compound 3: the middle estimate sits 2 percentage points below what was measured; the measured number falls inside the stated range.
By their numbers in this assay, from the lowest: compounds 2, 3 and 1 (each within the scatter of the next).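

In this assay, hydrogen in place of methoxy on an aromatic carbon, ortho to a methoxy group, gives a number 2 percentage points higher from compound 2 to compound 3 (within the scatter), so the 3,4-dimethoxyphenyl and 4-methoxyphenyl compounds cannot be separated at the single concentration tested. Methoxy in place of amino on an aromatic carbon gives a number 3 percentage points lower from compound 1 to compound 3 (within the scatter), which adds a second single-place exchange on this aryl that also stays within the scatter, and all three aryl ketones remain unordered in this read-out. No supporting measurement bears on the reason for this outcome.

From the compounds shown here alone, whether a carboxylic acid or a chlorine atom on this aryl, or replacement of a methoxy on the trimethoxyphenyl ring by a hydroxyl, would give a number beyond the scatter of these values remains open. Also open, going by these compounds, is whether the three compounds would separate at other concentrations, as the one concentration in this assay gives the size of the read-out and not a potency for any of them.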